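Series notes: urea terminus of compound 3 and next step

The compounds below may be only part of what the source reports. "The series", "measured", "known", "first", "only" and "open" are said of these compounds alone.

Compound 3 `CC(C)(N)C(=O)N[C@@H]1CCc2ccccc2N(Cc2ccc(-c3ccccc3CNC(=O)NCc3ccccc3)cc2)C1=O` gives 390 nM in a functional assay (Pituitary gland cell) with Rattus norvegicus as the target (a lower number here means that less compound is needed, a higher number that more compound is needed for the effect), the highest of the three numbers measured; compound 2 `CCCNC(=O)NCc1ccccc1-c1ccc(CN2C(=O)[C@H](NC(=O)C(C)(C)N)CCc3ccccc32)cc1` gives 144 nM and compound 1 `CC(C)(N)C(=O)N[C@@H]1CCc2ccccc2N(Cc2ccc(-c3ccccc3CNC(=O)NCCO)cc2)C1=O` gives 2 nM. Compound 4 `CN(C)C(=O)NCc1ccccc1-c1ccc(CN2C(=O)[C@H](NC(=O)C(C)(C)N)CCc3ccccc32)cc1` differs from compound 3 by dimethylamino in place of benzylamino on a carbonyl carbon. The step that bears most directly is a 2.7-fold higher number from compound 2 to compound 3 (0.43 log units; beyond the scatter), a modest shift on trading a small alkyl for phenyl at the urea terminus; a 72-fold higher number from compound 1 to compound 2 (1.86 log units; beyond the scatter) shows a hydroxy there is worth far more, and compound 4 carries none. Removing the phenyl is therefore expected to lower the number to roughly the level of compound 2, no further, giving an estimated 2.6-fold lower number from compound 3 to compound 4 (0.41 log units; beyond the scatter). Compound 4 is estimated at 150 nM, within 40 nM to 600 nM.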

Compound 4, concentration for half-maximal effect: 60 nM
For compound 4 the middle estimate is 2.5-fold (0.40 log units) above the measured one; the range from low to high includes it.
By their numbers in this assay, from the lowest: compound 1; then compound 4; then compound 2; then compound 3.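

In this assay the urea terminus does not need a hydrogen-bond donor on the nitrogen bound to the carbonyl carbon: dimethylamino gives a 6.5-fold lower number from compound 3 to compound 4 (0.81 log units; beyond the scatter) and a 2.4-fold lower number from compound 2 to compound 4 (0.38 log units; beyond the scatter) on the same change. Dimethylamino still does not match (2-hydroxyethyl)amino, with a 30-fold higher number from compound 1 to compound 4 (1.48 log units; beyond the scatter) as the gap that remains. No measurement in hand gives a reason for these shifts.

Open, on these data alone, is whether the hydroxy or the chain carrying it sets the low value of compound 1. Methylamino, (2-methoxyethyl)amino and (3-hydroxypropyl)amino at this carbonyl carbon would separate these readings.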